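The compounds below may be only part of what the source reports. "The series", "measured", "known", "first", "only" and "open" are said of these compounds alone.

Working notes on the series in a functional assay on Right cardiac atrium for agonist activity at histamine H2 receptor (Cavia porcellus), with a stated time of 30 min, in the presence of a further agent that is not named here; on this read-out higher numbers stand for larger maximal responses and lower numbers for smaller maximal responses.

Going by the values given here, compound 1, `Cc1nc(N)sc1CCCN/C(N)=N/C(=O)N[C@H](C)c1ccccc1`, carries the shared core with a benzylic stereocentre drawn R. In this assay compound 1 gives 0.95, the highest of the two numbers measured so far. Compound 2, `Cc1nc(N)sc1CCCN/C(N)=N/C(=O)NC(C)c1ccc(Br)cc1`, differs in both the ring substitution and the drawn configuration; in this assay compound 2 gives 0.87, a gap to compound 1 that lies within the usual scatter, so nothing can be said about order between these two.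

Compound 3, `Cc1nc(N)sc1CCCN/C(N)=N/C(=O)N[C@@H](C)c1ccccc1`, is not yet measured. Relative to compound 1 the change is the two compounds have the same atoms and bonds and differ only in configuration as drawn: 1 of 2 stereo elements differ; a stereocentre at a saturated chain carbon is drawn R in compound 1 and S in compound 3. Among the compounds with values here, no pair among the measured compounds isolates this change, so no measured step anchors the expectation. Both measured compounds reach large maximal responses despite their different drawn configurations, which gives no sign that the configuration alone moves this read-out beyond the scatter.

The expected step from compound 1 to compound 3 is a number 0.050 lower from compound 1 to compound 3 (within the scatter), essentially none beyond the scatter. Compound 3 is therefore expected to give 0.9, with a range from 0.75 to 1.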

Compound 3, intrinsic activity: the largest response reached, as a fraction of the reference agonist's: 1.08
For compound 3 the middle estimate is 0.18 below the measured one; the whole stated range lies below it.
By their numbers in this assay, from the lowest: compounds 2 and 1 (each within the scatter of the next); then compound 3.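

The stereocentre at the saturated chain carbon is not silent on this read-out: in this assay the change from R to S gives a number 0.13 higher from compound 1 to compound 3 (beyond the scatter). Going by these compounds alone, compound 1 and compound 2 differ in more than one place and could not isolate any single change, so this pair gives the first reading of configuration alone. The step can be assigned to the stereocentre and to nothing else in the structure, because no atom or bond separates the pair: the fact that compounds 1 and 3 differ only in the configuration as drawn.

From the compounds shown here alone, this is a single pair on the unsubstituted phenyl background, so it remains open whether the S drawing gives the higher maximal response when the ring carries the bromine of compound 2, or whether the size of the step would hold there. It also remains open how the stereocentre behaves when an ethyl group takes the place of its methyl group, and the compounds shown say nothing about how the two configurations compare on any other read-out.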